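A few compounds are considered here, and "the series" means these few. Any claim that something is new, unique, unknown or untested is made for them only; others in the source may bear on it.

Of the compounds shown here, two have numbers so far in a functional assay on MCF7 cells (Homo sapiens) for inhibition, read by MTT assay, with a stated time of 48 h; on this read-out higher numbers stand for weaker inhibition of growth and lower numbers for stronger inhibition of growth. Compound 1 `Cn1cc(C2CC(c3ccccc3)=NN2C(=O)c2ccncc2)c2ccccc21` gives 1110 nM, and compound 2 `COc1ccc2c(c1)c(C1CC(c3ccc(F)cc3)=NN1C(=O)c1ccc(OC)nc1)cn2C` gives 480 nM. Compound 2 therefore holds the lower of the two numbers, meaning stronger inhibition of growth, and the gap between them lies beyond the usual scatter of repeated measurements. Compound 3 `COc1ccc2c(c1)c(C1CC(c3cc(OC)c(OC)c(OC)c3)=NN1C(=O)c1ccc(OC)nc1)cn2C` is compound 2 with a single group exchanged: 3,4,5-trimethoxyphenyl in place of 4-fluorophenyl on a carbon with a double bond to nitrogen. The exchange takes place on a carbon with a double bond to nitrogen. Within the data shown here, no two measured compounds differ in one place only, so nothing yet shows what a change at this position does, and any expectation must stay loose. A small move towards a lower number is expected, one that may well stay within the scatter. In this assay the expected step is a 1.6-fold lower number from compound 2 to compound 3 (0.20 log units; within the scatter). For compound 3 the estimate is 300 nM, with an expected range from 80 nM to 1100 nM.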

Compound 3, concentration for 50% growth inhibition: > 10000 nM
Compound 3: no number, only a limit; the forecaster's own chance of this, stated with the estimate: 3%; middle value at least 33-fold (1.52 log units) from the limit.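

Among these compounds, this is the first pair that differs in one place only, and in this assay it gives an at least 20-fold higher number from compound 2 to compound 3 (1.31 log units; beyond the scatter). The position on the carbon with a double bond to nitrogen therefore tolerates not every aryl group: with the rest of compound 2 unchanged, 3,4,5-trimethoxyphenyl in place of 4-fluorophenyl is enough to take away most of the inhibition of growth. For compound 3 the reading > 10000 nM is a limit of the assay and not a number: the limit of > 10000 nM in this assay, at which 1 of the 3 values shown sits.

This single exchange removes a fluorine and adds three methoxy groups at once, so the compounds shown cannot say which part of it matters. They also leave open how this position would respond to a smaller change, such as a chlorine atom or an amine on the phenyl ring.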